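The source may report more compounds than this note shows. Statements on the series, on what has been measured and on what is new or still open speak of the compounds shown alone.

Compound 1 `O=C(CSc1nc(Nc2ccccc2)c2ccccc2n1)Nc1cccc(F)c1` gives the lowest number of the three measured in a functional assay on NCI-H1975 cells (Homo sapiens) for inhibition, read by MTT assay, with a stated time of 72 h (on this read-out higher numbers stand for weaker inhibition and lower numbers for stronger inhibition), at 6790 nM. Compound 2 `O=C(CSc1nc(Nc2ccccc2)c2ccccc2n1)Nc1ccc(F)cc1` gives 16500 nM in this assay, and compound 3 `O=C(CSc1nc(Nc2ccccc2)c2ccccc2n1)Nc1ccc(C(F)(F)F)cc1` gives 11700 nM. The step of a 2.4-fold higher number from compound 1 to compound 2 (0.39 log units; beyond the scatter) is modest but beyond the scatter, while a 1.7-fold higher number from compound 1 to compound 3 (0.24 log units; within the scatter) and a 1.4-fold lower number from compound 2 to compound 3 (0.15 log units; within the scatter) stay within it. Compound 4 `O=C(CSc1nc(Nc2ccccc2)c2ccccc2n1)Nc1ccc(F)c(Cl)c1` differs from compound 1 by 3-chloro-4-fluorophenyl in place of 3-fluorophenyl on an amide-type nitrogen. Going by the values given here, the only step bearing on this is a 2.4-fold higher number from compound 1 to compound 2 (0.39 log units; beyond the scatter), where fluorine on the same ring position that compound 4 now carries was added in exchange for the ring substituent that compound 4 retains; no measured step covers chloro on this ring. The expected step of a 1.2-fold higher number from compound 1 to compound 4 (0.07 log units; within the scatter) is therefore small, likely within the scatter. Compound 4 is expected to give 8000 nM, with a range of 3000 nM to 20000 nM.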

Compound 4, half-maximal inhibitory concentration: 9390 nM
The estimate for compound 4 lay 1.2-fold (0.07 log units) below the measured number, within the range that was stated.
By their numbers in this assay, from the lowest: compounds 1, 4, 3 and 2 (each within the scatter of the next, the first and the last beyond it).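

Chloro in place of hydrogen on an aromatic carbon reads (a 1.8-fold lower number from compound 2 to compound 4 (0.24 log units; within the scatter)) in this assay, the first chloro seen on this ring. Against the other two aryl groups on the amide-type nitrogen, 3-chloro-4-fluorophenyl reads (a 1.4-fold higher number from compound 1 to compound 4 (0.14 log units; within the scatter)) and (a 1.2-fold lower number from compound 3 to compound 4 (0.10 log units; within the scatter)), so all three steps stay within the scatter and this second halogen shifts no number beyond it. Nothing available explains these steps.

On these data alone, whether an amine or a carboxylic acid on this ring would leave this narrow band stays open. So does the effect of any change to the shared core.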